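Nitrile placement on the triazole aryl ring

The source may report more compounds than this note shows. Statements on the series, on what has been measured and on what is new or still open speak of the compounds shown alone.

In a functional assay on COLO 205 cells (Homo sapiens) for cytotoxicity, read by MTT assay, with a stated time of 24 h (a lower number here means a stronger inhibitor, a higher number a weaker inhibitor), compound 1 `COc1ccc(/C=C\C(=O)O)c(OCc2cn(-c3cccc(C#N)c3)nn2)c1CC=C(C)C` gives 26800 nM. Compound 2 `COc1ccc(/C=C\C(=O)O)c(OCc2cn(-c3ccccc3)nn2)c1CC=C(C)C` gives 32300 nM; the step of a 1.2-fold higher number from compound 1 to compound 2 (0.08 log units; within the scatter) lies within the scatter, so on the two numbers available compound 2 sits level with compound 1. Compound 3 `COc1ccc(/C=C\C(=O)O)c(OCc2cn(-c3ccccc3C#N)nn2)c1CC=C(C)C` differs from compound 2 by cyano in place of hydrogen on an aromatic carbon. For the measured compounds named here, the only measured step that bears on this is a 1.2-fold higher number from compound 1 to compound 2 (0.08 log units; within the scatter), which involved the same cyano group on the same ring and was flat, so no movement beyond the scatter is expected in this assay. Compound 3 is therefore estimated at 28000 nM, range 14000 nM to 56000 nM, an expected step of a 1.2-fold lower number from compound 2 to compound 3 (0.06 log units; within the scatter).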

Compound 3, half-maximal inhibitory concentration: 3200 nM
Estimate against measurement, compound 3: 8.8-fold (0.94 log units) above; measured number below the stated range.
By their numbers in this assay, from the lowest: compound 3; then compounds 1 and 2 (each within the scatter of the next).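

In this assay the change from phenyl to 2-cyanophenyl gives a 10-fold lower number from compound 2 to compound 3 (1.00 log units; beyond the scatter) and thus counts at this place, ortho to a large group. With 2-cyanophenyl in place of 3-cyanophenyl, the series shows an 8.4-fold lower number from compound 1 to compound 3 (0.92 log units; beyond the scatter) so the gain follows the placement of the nitrile and not its mere presence on the ring. Nothing at hand accounts for this gain.

On these data alone, whether the gain is particular to the nitrile stays open. A chlorine atom, a methoxy group or a carboxamide at the same place would test this.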